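Methoxy on a Fused Core: Expected Cytotoxicity of Compound 4

The source may report more compounds than this note shows. Statements on the series, on what has been measured and on what is new or still open speak of the compounds shown alone.

Measured compounds:
compound 1, `O=C(Nc1ccc(I)cc1F)c1ccccc1OCc1ccc(F)cc1F`: 32600 nM
compound 2, `O=c1oc2ccccc2c(=O)n1-c1ccc(I)cc1F`: 23600 nM
compound 3, `COc1ccc(C(=O)Nc2ccc(I)cc2F)c(OCc2ccc(F)cc2F)c1`: 36800 nM

These three were tested in an ADME assay on RAW264.7 cells (Mus musculus) for cytotoxicity, read by MTT assay, with a stated time of 24 h; on this read-out lower numbers stand for higher toxicity in this test and higher numbers for lower toxicity in this test. Compound 1 and compound 3 share a core, and compound 3 carries the change (methoxy in place of hydrogen on an aromatic carbon). That step gave a 1.1-fold higher number from compound 1 to compound 3 (0.05 log units; within the scatter). Compound 2 has a different core; how the two cores differ is not broken down here.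

Compound 4, `COc1ccc2c(=O)n(-c3ccc(I)cc3F)c(=O)oc2c1`, has not yet been measured. It differs from compound 2 by methoxy in place of hydrogen on an aromatic carbon. This is the same kind of change as in compound 3, but the place is not identical: here the ring is part of a fused or bridged system of two rings, meta to a fused ring and para to a fused ring, whereas in compound 3 the methoxy sits meta to a large group and para to a large group.

Because compound 3 showed a 1.1-fold higher number from compound 1 to compound 3 (0.05 log units; within the scatter), compound 4 is expected to show a 1.1-fold higher number from compound 2 to compound 4 (0.04 log units; within the scatter), a step within the scatter. Compound 4 is therefore estimated at 26000 nM, with a likely range from 13000 nM to 52000 nM.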

Compound 4, half-maximal cytotoxic concentration: 30100 nM
Beside the measured number, compound 4's estimate is 1.2-fold (0.06 log units) below it; measured number inside the range.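

In this assay, methoxy in place of hydrogen on an aromatic carbon gave a 1.3-fold higher number from compound 2 to compound 4 (0.11 log units; within the scatter), so on this core the effect cannot be told apart from ordinary variation between repeat measurements. The earlier step on the other core looks much the same: the same change on two cores in this assay, a 1.1-fold higher number (0.05 log units; within the scatter) from compound 1 to compound 3 and a 1.3-fold higher number (0.11 log units; within the scatter) from compound 2 to compound 4, 1.1-fold (0.05 log units) apart, within the scatter of two such steps. This shows that the change carried across these two cores without a detectable effect on the read-out, but two pairs cannot show that it would do so on every core in the series or at every place on the ring.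

The compounds shown leave open whether another group at this place, such as an amine or a carboxylic acid, would give a step beyond the scatter.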